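From 3-methoxyphenyl to 3-fluorophenyl: working notes on the series

This account rests on a few compounds, and the source may have more. Where it says the series, first, only, none or still open, it means among the compounds named here.

compound 1 `CCC1=C(O)c2c(oc(-c3ccc(OC)cc3)cc2=O)C(CC)(CC)C1=O` gives 17.7 uM in a functional assay on KB cells (Homo sapiens) for antiproliferative activity, read by sulforhodamine B assay, with a stated time of 3 days; on this read-out lower numbers stand for an effect already at smaller amounts and higher numbers for an effect only at larger amounts of compound
compound 2 `CCC1=C(O)c2c(oc(-c3cccc(C)c3)cc2=O)C(CC)(CC)C1=O` gives 49.7 uM in this assay
compound 3 `CCC1=C(O)c2c(oc(-c3cccc(OC)c3)cc2=O)C(CC)(CC)C1=O` gives 13.3 uM in this assay

Compound 3 stands at the low end of these numbers, level with compound 1. The gap between those two is a 1.3-fold lower number from compound 1 to compound 3 (0.12 log units; within the scatter) and gives them no order. Compound 2 stands apart, with a 3.7-fold lower number from compound 2 to compound 3 (0.57 log units; beyond the scatter) marking the distance.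

The next change leads to compound 4 `CCC1=C(O)c2c(oc(-c3cccc(F)c3)cc2=O)C(CC)(CC)C1=O` and puts fluoro in place of methoxy on an aromatic carbon, meta to a large group (fluoro in place of methoxy on an aromatic carbon). Among the compounds with values here, no fluoro compound has been measured, so the guidance is indirect. Within the data shown here, the closest measured swap is a 3.7-fold lower number from compound 2 to compound 3 (0.57 log units; beyond the scatter) and it is the only one that exchanges another group for this methoxy. Relocating the methoxy gave a 1.3-fold lower number from compound 1 to compound 3 (0.12 log units; within the scatter) and so offers no warning. Among the measured compounds shown here, the one compound without a methoxy, compound 2, came with a 2.8-fold higher number from compound 1 to compound 2 (0.45 log units; beyond the scatter) and that points the same way. A modest move towards a higher number is therefore expected, possibly not clear of the scatter. The expected change is a 1.9-fold higher number from compound 3 to compound 4 (0.27 log units; within the scatter) in this assay on this reasoning. For compound 4 the estimated value is 25 uM with an expected range from 10 uM to 60 uM as the upper end.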

Compound 4, concentration for half-maximal effect: > 56.2 uM
Compound 4 gave a limit, no number (the forecaster's own chance of this, stated with the estimate: 5%); middle value at least 2.2-fold (0.35 log units) from the limit.
By their numbers in this assay, from the lowest: compounds 3 and 1 (each within the scatter of the next); then compound 2. At a limit, above all of these: compound 4.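

Compound 4 gives only a limit, not a number, in this assay: the limit of > 56.2 uM in this assay, at which 1 of the 4 values shown sits. Fluoro in place of methoxy on this aromatic carbon, meta to a large group, gives an at least 4.2-fold higher number from compound 3 to compound 4 (0.62 log units; beyond the scatter), and the comparison with the 4-methoxyphenyl compound gives an at least 3.1-fold higher number from compound 1 to compound 4 (0.50 log units; beyond the scatter), so the fluoro compound now separates from both methoxy compounds. Fluoro in place of methyl gives an at least 1.1-fold higher number from compound 2 to compound 4 (0.05 log units; that floor lies within the scatter), which leaves those two groups without an order; among the four compounds shown, the 3-methoxyphenyl and 4-methoxyphenyl groups go with the lower numbers, and no compound goes against this.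

On these data alone, how far compound 4 lies past its limit remains open, and so does whether the higher numbers follow from losing the methoxy as such, since only methyl and fluoro stand in its place here. A hydroxy group, an amine or a longer ether such as ethoxy on the same aromatic carbon would show whether the methoxy is specifically needed or whether other groups can serve there as well.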